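This account rests on a few compounds, and the source may have more. Where it says the series, first, only, none or still open, it means among the compounds named here.

Compound 1 `CCCCCCS(=O)(=O)/C=C/c1ccc(O)c(O)c1` has the lowest number of the three in a functional assay, read by fluorescence and spectrophotometry, with a stated time of 1 h (on this read-out higher numbers stand for an effect only at larger amounts of compound and lower numbers for an effect already at smaller amounts), giving 7300 nM, although the two other compounds sit within the scatter of it. Compound 2 `O=S(=O)(/C=C/c1ccc(O)c(O)c1)CC1CCCO1` gives 10500 nM, and compound 3 `CCCCCCCCCCCS(=O)(=O)/C=C/c1ccc(O)c(O)c1` gives 11400 nM. Both steps, a 1.4-fold higher number from compound 1 to compound 2 (0.16 log units; within the scatter) and a 1.6-fold higher number from compound 1 to compound 3 (0.19 log units; within the scatter), stay within the scatter. Compound 4 `CCCCCCCCS(=O)(=O)/C=C/c1ccc(O)c(O)c1` differs from compound 1 by ethyl in place of hydrogen on a saturated chain carbon, six bonds along the chain from a sulfonyl sulfur. The step that bears on this change is a 1.6-fold higher number from compound 1 to compound 3 (0.19 log units; within the scatter), where a longer chain at the same place moved the number only within the scatter. A shorter extension is therefore expected to do no more, so no step beyond the scatter is expected in this assay. For compound 4 the estimate is 8500 nM, in the range 4000 nM to 18000 nM, meaning an expected 1.2-fold higher number from compound 1 to compound 4 (0.07 log units; within the scatter).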

Compound 4, half-maximal effective concentration: 6400 nM
Compound 4: the middle estimate sits 1.3-fold (0.12 log units) above what was measured; the measured number falls inside the stated range.
By their numbers in this assay, from the lowest: compounds 4, 1, 2 and 3 (each within the scatter of the next).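

In this assay, ethyl in place of hydrogen at this place on the chain stays within the scatter (a 1.1-fold lower number from compound 1 to compound 4 (0.06 log units; within the scatter)), so a short extension now joins the longer one in leaving the number there. Removing propyl further out also stays within the scatter (a 1.8-fold lower number from compound 3 to compound 4 (0.25 log units; within the scatter)), as does heptyl in place of oxolan-2-yl (a 1.6-fold lower number from compound 2 to compound 4 (0.22 log units; within the scatter)), so no chain or ring compared here separates these compounds. Open, on these data alone, is whether an amine or a carboxylic acid on the chain would give a step beyond the scatter. Nothing offered here accounts for these small steps.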